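Swapping Fluoro for Chloro on the Core of Compound 2

The source may report more compounds than this note shows. Statements on the series, on what has been measured and on what is new or still open speak of the compounds shown alone.

Compound 1 `O=C1/C(=C/c2ccccc2)CCC/C1=C\c1cccc([N+](=O)[O-])c1` gives 1700 nM in a functional assay on MOLT-4 cells (Homo sapiens) for cytotoxicity, with a stated time of 72 h; on this read-out higher numbers stand for weaker inhibition and lower numbers for stronger inhibition. Compound 2 `O=C1/C(=C/c2ccc(F)cc2)CCC/C1=C\c1cccc([N+](=O)[O-])c1`, which carries a fluoro on one of its aromatic rings, gives 5120 nM in this assay. The step of a 3.0-fold higher number from compound 1 to compound 2 (0.48 log units; beyond the scatter) shows that introducing the fluoro weakened the inhibition. On the two numbers available, compound 2 stands with the highest number, and the nearest is compound 1 at 1700 nM.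

Compound 3 `O=C1/C(=C/c2ccc(Cl)cc2)CCC/C1=C\c1cccc([N+](=O)[O-])c1` has not yet been measured. It differs from compound 2 by chloro in place of fluoro on an aromatic carbon. For the measured compounds named here, the only measured step touching this part of the molecule is a 3.0-fold higher number from compound 1 to compound 2 (0.48 log units; beyond the scatter), which concerns placing a halogen there at all rather than exchanging one halogen for another; no measured pair exchanges fluoro for chloro, so the direction is not settled by the data. The step of a 1.0-fold lower number from compound 2 to compound 3 (0.01 log units; within the scatter) is therefore expected to be small, likely within the scatter, with either direction possible. Compound 3 is accordingly estimated at 5000 nM in this assay, with a range from 2000 nM to 12500 nM.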

Compound 3, half-maximal inhibitory concentration: 2020 nM
Beside the measured number, compound 3's estimate is 2.5-fold (0.39 log units) above it; measured number inside the range.
By their numbers in this assay, from the lowest: compounds 1 and 3 (each within the scatter of the next); then compound 2.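

In this assay, the exchange of 4-fluorophenyl for 4-chlorophenyl gives a 2.5-fold lower number from compound 2 to compound 3 (0.40 log units; beyond the scatter), so this position distinguishes between the two halogens, whereas the earlier pair compared only fluoro with hydrogen. Chloro in place of hydrogen gives a 1.2-fold higher number from compound 1 to compound 3 (0.07 log units; within the scatter), so the shift beyond the scatter seen on adding fluoro does not extend to every halogen at this place: among these three compounds, only the fluoro compound stands apart. Nothing measured here bears on why fluoro and chloro part at this position.

The compounds shown carry only hydrogen, fluoro or chloro at this place, so it remains open whether a bromo, a methoxy or an amine group would group with compound 1 and compound 3 or with compound 2. On these data alone, it also remains open whether the gap between fluoro and chloro would persist if the nitro group on the other aromatic ring were replaced by a carboxylic acid.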